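Shortening the Amide Tail: Expected Cytotoxicity of Compound 4

A few compounds are considered here, and "the series" means these few. Any claim that something is new, unique, unknown or untested is made for them only; others in the source may bear on it.

Three compounds share one core and differ only in what hangs from the amide nitrogen. In an ADME assay on MT4 cells (Homo sapiens) for cytotoxicity, read by MTT assay (on this read-out higher numbers stand for lower toxicity in this test and lower numbers for higher toxicity in this test), compound 1 `Cc1cc(C)cc(S(=O)(=O)c2c(C(=O)NC(C)C(=O)NCc3ccccc3F)[nH]c3ccc(Cl)cc23)c1` gives 23300 nM, and compound 2 `Cc1cc(C)cc(S(=O)(=O)c2c(C(=O)NCC(=O)NCCn3c(C)cnc3[N+](=O)[O-])[nH]c3ccc(Cl)cc23)c1` gives 24500 nM. For compound 3 `Cc1cc(C)cc(S(=O)(=O)c2c(C(=O)NCC(=O)NCc3ccncn3)[nH]c3ccc(Cl)cc23)c1` this assay reports only a limit, > 48800 nM. Within the data shown here, the single measured step, an at least 1.9-fold higher number from compound 2 to compound 3 (0.29 log units; that floor lies within the scatter), is itself a floor that rests on (the limit of > 48800 nM in this assay, at which 1 of the 3 values shown sits). Compound 4 `COc1cccc(F)c1CNC(=O)c1[nH]c2ccc(Cl)cc2c1S(=O)(=O)c1cc(C)cc(C)c1` differs from compound 3 by 2-fluoro-6-methoxyphenyl in place of ((pyrimidin-4-yl)methyl)carbamoyl on a saturated chain carbon bound to an amide-type nitrogen. Among the measured compounds shown here, no measured step removes the second amide in this way, so the step from compound 2 to compound 3 gives only loose guidance; all three numbers sit at weak toxicity, and compound 4 is expected to stay there. The step of an at least 1.6-fold lower number from compound 3 to compound 4 (0.21 log units; that floor lies within the scatter) is expected to be small. Compound 4 is estimated at 30000 nM, between 10000 nM and 60000 nM.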

Compound 4, half-maximal cytotoxic concentration: > 49900 nM
Compound 4 ended at the assay's limit; the forecaster's own chance of this, stated with the estimate: 35%; middle value at least 1.6-fold (0.22 log units) from the limit.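

Compound 3 and compound 4 each give only a limit in this assay, so the step between them cannot be read. The compounds shown leave open which of the two is less toxic in this test.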